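Para substituent on the urea aryl ring, three measurements

The source may report more compounds than this note shows. Statements on the series, on what has been measured and on what is new or still open speak of the compounds shown alone.

Measured in a functional assay on A-431 cells (Homo sapiens) for antiproliferative activity, read by MTT assay, with a stated time of 72 h; on this read-out lower numbers stand for stronger inhibition and higher numbers for weaker inhibition:
compound 1 `O=C(Nc1ccc(CN2CCCCC2)cc1)Nc1ccc2ncnc(Nc3cccc(C(F)(F)F)c3)c2c1`: 1550 nM
compound 2 `CN(C)Cc1ccc(NC(=O)Nc2ccc3ncnc(Nc4cccc(C(F)(F)F)c4)c3c2)cc1`: 1030 nM
compound 3 `COc1ccc(NC(=O)Nc2ccc3ncnc(Nc4cccc(C(F)(F)F)c4)c3c2)cc1`: 4950 nM

Compound 3 stands highest of the three numbers. The steps of a 3.2-fold higher number from compound 1 to compound 3 (0.50 log units; beyond the scatter) and a 4.8-fold higher number from compound 2 to compound 3 (0.68 log units; beyond the scatter) both lie beyond the scatter, whereas a 1.5-fold lower number from compound 1 to compound 2 (0.18 log units; within the scatter) lies within it, so compounds 1 and 2 are not distinguished from each other on this read-out.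

Compound 4 `CN1CCN(c2ccc(NC(=O)Nc3ccc4ncnc(Nc5cccc(C(F)(F)F)c5)c4c3)cc2)CC1` is not yet measured. Its change from compound 3 is 4-methylpiperazin-1-yl in place of methoxy on an aromatic carbon. The two steps that bear on it are the ones that took compounds 1 and 2 to compound 3, each a replacement of a nitrogen-bearing substituent by methoxy and each a modest rise in number; compound 4 runs that exchange backwards. Among the compounds with values here, the match is not exact: in compound 4 the ring nitrogen sits directly on the aromatic carbon, with no saturated chain carbon between, and no measured step covers that arrangement. A lower number than compound 3 is nevertheless expected, of about the size a 3.3-fold lower number from compound 3 to compound 4 (0.52 log units; beyond the scatter). Compound 4 is estimated at 1500 nM, with a range from 500 nM to 4500 nM.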

Compound 4, half-maximal inhibitory concentration: 2200 nM
Compound 4: the middle estimate sits 1.5-fold (0.17 log units) below what was measured, and the stated range covers the measured number.
By their numbers in this assay, from the lowest: compounds 2, 1 and 4 (each within the scatter of the next, the first and the last beyond it); then compound 3.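

In this assay, a nitrogen-bearing ring attached directly to the aromatic carbon, with no saturated chain carbon, still gives a lower number than methoxy (a 2.3-fold lower number from compound 3 to compound 4 (0.35 log units; beyond the scatter)), so all three nitrogen-bearing groups now stand below compound 3. The directly attached group does not match every chain-linked one: compound 4 is separated from the dimethylamino analogue (a 2.1-fold higher number from compound 2 to compound 4 (0.33 log units; beyond the scatter)) but not from the piperidine analogue (a 1.4-fold higher number from compound 1 to compound 4 (0.15 log units; within the scatter)). No measurement shown accounts for these differences.

Compounds 2 and 4 differ in both the amine and its attachment, so the contribution of the saturated chain carbon remains unresolved; a (4-methylpiperazin-1-yl)methyl group would separate the two. A morpholin-4-yl group, with oxygen in place of the methylated ring nitrogen, would show whether that nitrogen matters at this position.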